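Fluorophenoxy ketones: from difluoro to tetrafluoro

The compounds below may be only part of what the source reports. "The series", "measured", "known", "first", "only" and "open" are said of these compounds alone.

Measured compounds:
compound 1 `CC(C)[C@H](NC(=O)COc1cccc2ccccc12)C(=O)N[C@@H](CC(=O)O)C(=O)COc1ccccc1F` gives 15700 nM in a functional assay with Homo sapiens as the target; on this read-out lower numbers stand for stronger inhibition and higher numbers for weaker inhibition
compound 2 `CC(C)[C@H](NC(=O)COc1cccc2ccccc12)C(=O)N[C@@H](CC(=O)O)C(=O)COc1ccc(F)cc1` gives 14300 nM
compound 3 `CC(C)[C@H](NC(=O)COc1cccc2ccccc12)C(=O)N[C@@H](CC(=O)O)C(=O)COc1ccc(F)cc1F` gives 17600 nM

The three numbers lie within the scatter of one another. Compound 3 differs from compound 1 by a 1.1-fold higher number from compound 1 to compound 3 (0.05 log units; within the scatter) and from compound 2 by a 1.2-fold higher number from compound 2 to compound 3 (0.09 log units; within the scatter); the move between the two monofluoro compounds, a 1.1-fold lower number from compound 1 to compound 2 (0.04 log units; within the scatter), is equally flat. Nothing in this set separates one fluorine pattern on the phenyl from another.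

Compound 4 `CC(C)[C@H](NC(=O)COc1cccc2ccccc12)C(=O)N[C@@H](CC(=O)O)C(=O)COc1c(F)c(F)cc(F)c1F` is the next step from compound 3. The change is 2,3,5,6-tetrafluorophenyl in place of 2,4-difluorophenyl on an oxygen on a saturated carbon.

For the measured compounds named here, the steps that bear on it are the two additions of fluoro in place of hydrogen on an aromatic carbon, a 1.1-fold higher number from compound 1 to compound 3 (0.05 log units; within the scatter) and a 1.2-fold higher number from compound 2 to compound 3 (0.09 log units; within the scatter), and the repositioning step a 1.1-fold lower number from compound 1 to compound 2 (0.04 log units; within the scatter); all three stayed within the scatter. Compound 4 adds two further fluorines on the same ring, a larger change than any measured here, so the expectation carries more uncertainty, but the measured steps give no ground for a shift in either direction beyond the scatter.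

Compound 4 is therefore expected at about 18000 nM, with a range from 8000 nM to 40000 nM. The step expected here is a 1.0-fold higher number from compound 3 to compound 4 (0.01 log units; within the scatter).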

Compound 4, half-maximal inhibitory concentration: 6250 nM
For compound 4 the middle estimate is 2.9-fold (0.46 log units) above the measured one; the measured number lies below the stated range.
By their numbers in this assay, from the lowest: compound 4; then compounds 2, 1 and 3 (each within the scatter of the next).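

At this position, on an oxygen on a saturated carbon, the phenyl substitution does register in this assay: 2,3,5,6-tetrafluorophenyl gives a 2.8-fold lower number from compound 3 to compound 4 (0.45 log units; beyond the scatter), along with a 2.3-fold lower number from compound 2 to compound 4 (0.36 log units; beyond the scatter) and a 2.5-fold lower number from compound 1 to compound 4 (0.40 log units; beyond the scatter), all three modest but beyond the scatter. For the compounds shown here, the monofluoro and difluoro compounds gave no separation among themselves, so compound 4 is the first member of the set to stand apart, and it has the lowest number of the four. No supporting data bear on why this ring behaves differently from the others, so the step stands as an observation only.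

Compound 4 differs from compounds 1, 2 and 3 in both the number of fluorines and their arrangement on the ring, so the compounds shown cannot tell whether the count, the pattern or the combination goes with the lower number. Also open, from the compounds shown here alone, is whether the trend extends to pentafluorophenyl, and whether a ring bearing chloro or methoxy in place of fluoro would move the read-out in the same direction.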